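A few compounds are considered here, and "the series" means these few. Any claim that something is new, unique, unknown or untested is made for them only; others in the source may bear on it.

Values measured in an ADME assay on HEp-2 cells (Homo sapiens) for cytotoxicity; on this read-out higher numbers stand for lower toxicity in this test and lower numbers for higher toxicity in this test:
- compound 1 `Cc1cccc(NC(=O)[C@@H]2CCCN2S(=O)(=O)c2cccc3cccnc23)c1`: 25500 nM
- compound 2 `Cc1ccc(NC(=O)[C@@H]2CCCN2S(=O)(=O)c2cccc3cccnc23)cc1`: 31700 nM
- compound 3 `Cc1cc(C)cc(NC(=O)[C@@H]2CCCN2S(=O)(=O)c2cccc3cccnc23)c1`: 31300 nM

Compound 3 cannot be separated from the other two on these numbers. The closest comparison is a 1.0-fold lower number from compound 2 to compound 3 (0.01 log units; within the scatter), and the other is a 1.2-fold higher number from compound 1 to compound 3 (0.09 log units; within the scatter). Both lie within the scatter, as does a 1.2-fold higher number from compound 1 to compound 2 (0.09 log units; within the scatter).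

The next entry is compound 4 `Cc1ccc(C)c(NC(=O)[C@@H]2CCCN2S(=O)(=O)c2cccc3cccnc23)c1`, and the change is 2,5-dimethylphenyl in place of 3,5-dimethylphenyl on an amide-type nitrogen. Within the data shown here, no measured compound carries the 2,5-dimethylphenyl group, so this exact arrangement is untested. The nearest evidence is the three steps among the aryl amides above, where changing the methyl groups on the ring has not moved this assay beyond the scatter. On that basis, no step beyond the scatter is expected. The expected result is a 1.0-fold lower number from compound 3 to compound 4 (0.02 log units; within the scatter). For compound 4 the estimated value is 30000 nM. The expected range for compound 4 runs from 17000 nM to 52000 nM.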

Compound 4, half-maximal cytotoxic concentration: 30900 nM
Estimate against measurement, compound 4: 1.0-fold (0.01 log units) below, within the range that was stated.
By their numbers in this assay, from the lowest: compounds 1, 4, 3 and 2 (each within the scatter of the next).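

Placing the same atoms as 2,5-dimethylphenyl in place of 3,5-dimethylphenyl on the amide-type nitrogen leaves this assay within the scatter (a 1.0-fold lower number from compound 3 to compound 4 (0.01 log units; within the scatter)). The 2,5-dimethylphenyl group also stays within the scatter against the 4-methylphenyl group (a 1.0-fold lower number from compound 2 to compound 4 (0.01 log units; within the scatter)) and the 3-methylphenyl group (a 1.2-fold higher number from compound 1 to compound 4 (0.08 log units; within the scatter)), so all four methyl-substituted aryl amides remain indistinguishable on this read-out. No supporting data bear on why this arrangement of methyl groups leaves the read-out flat.

From the compounds shown here alone, whether a carboxylic acid, a dimethylamino group or a longer alkyl chain on the phenyl ring would move this assay beyond the scatter remains open. Going by these compounds, all four compounds share the same core, so the effect of changes elsewhere in the structure also remains open.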